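The source may report more compounds than this note shows. Statements on the series, on what has been measured and on what is new or still open speak of the compounds shown alone.

Measured so far:

Compound 2, `COc1ccc(-c2cc(-c3ccccc3-c3ccccc3)n[nH]2)cc1`: 670 nM
Compound 1, `COc1ccc(-c2cc(-c3ccc([N+](=O)[O-])cc3)[nH]n2)cc1`: 27300 nM

In a functional assay on OVCAR cells (Homo sapiens) for inhibition, read by MTT assay, with a stated time of 48 h (on this read-out higher numbers stand for weaker inhibition of growth and lower numbers for stronger inhibition of growth), compound 2 stands at the lower of the two numbers, the stronger inhibition of growth. Compound 1, with a different core and a nitro group in place of the second ring, gives 27300 nM, a gap that lies well beyond the usual scatter; the two differ in more than one place, so nothing can be drawn from them about any single change.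

Compound 3, `Nc1ccc(-c2cc(-c3ccccc3-c3ccccc3)n[nH]2)cc1`, keeps the core of compound 2 and changes one group: amino in place of methoxy on an aromatic carbon. Among the measured compounds shown here, no measured pair carries this change, so its effect on this assay has to be guessed. The step of a 1.2-fold higher number from compound 2 to compound 3 (0.08 log units; within the scatter) is expected to be small, most likely within the scatter, in either direction. Compound 3 is therefore estimated at 800 nM, with a range from 250 nM to 2500 nM.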

Compound 3, concentration for 50% growth inhibition: 17900 nM
Beside the measured number, compound 3's estimate is 22-fold (1.35 log units) below it; the measured number lies above the stated range.
By their numbers in this assay, from the lowest: compound 2; then compounds 3 and 1 (each within the scatter of the next).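

With the rest of the molecule held fixed, amino in place of methoxy brings a 27-fold higher number from compound 2 to compound 3 (1.43 log units; beyond the scatter) in this assay, which means weaker inhibition of growth. This is the first pair shown that differs in one place only, so it gives the first clean reading of a single change: the swap from 4-methoxyphenyl to 4-aminophenyl is enough on its own to produce a large loss, and the group on this aromatic carbon, para to a large group, clearly matters. Nothing at hand explains why the step is so large.

Going by these compounds, it remains open whether a hydroxyl, a methyl or a dimethylamino group on this carbon would fall nearer compound 2 or compound 3. On these data alone, it is also open whether any group here would give stronger inhibition than the methoxy of compound 2.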